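Constrained diamine in place of the aminoethylamino chain of compound 2

The compounds below may be only part of what the source reports. "The series", "measured", "known", "first", "only" and "open" are said of these compounds alone.

Going by the values given here, compound 2 `NCCNc1c(C(=O)NCc2ccc(F)cc2)nc(Br)c2cccnc12` is the only member with a number in a functional assay on MDA-MB-435 cells (Homo sapiens) for cytotoxicity, read by MTT assay, with a stated time of 72 h (a higher number here means a weaker inhibitor, a lower number a stronger inhibitor), where compound 2 gives 12000 nM. Compound 1 `CS(=O)(=O)NCCCN(c1nc(C(=O)NCc2ccc(F)cc2)c(O)c2ncccc12)S(C)(=O)=O` reaches only the assay limit > 20000 nM in this assay. Compound 3 `O=C(NCCCNc1c(C(=O)NCc2ccc(F)cc2)nc(Br)c2cccnc12)c1ccccc1` likewise sits at the assay limit > 20000 nM in this assay. Among the compounds with values here, the one measured step, an at least 1.6-fold higher number from compound 2 to compound 3 (0.22 log units; that floor lies within the scatter), is the sole comparison on the same chain, and it has only a floor because compound 3 sits at the limit of > 20000 nM in this assay, at which 2 of the 3 values shown sit. Compound 4 `O=C(NCc1ccc(F)cc1)c1nc(Br)c2cccnc2c1N1CCNCC1` carries piperazin-1-yl in place of (2-aminoethyl)amino on an aromatic carbon. Within the data shown here, no measured step covers a ring closure of this kind, so the expectation is that compound 4 stays close to compound 2, with a modest weakening possible. Compound 4 is estimated at 15000 nM in this assay, between 5000 nM and 40000 nM. The expected step of a 1.3-fold higher number from compound 2 to compound 4 (0.10 log units; within the scatter) is estimated to lie within the scatter.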

Compound 4, half-maximal inhibitory concentration: 8000 nM
Compound 4: middle estimate off by 1.9-fold (0.27 log units), on the high side; measured number inside the range.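

At this aromatic carbon, para to a bromo group, piperazin-1-yl in place of (2-aminoethyl)amino gives a 1.5-fold lower number from compound 2 to compound 4 (0.18 log units; within the scatter) in this assay. Closing the open chain into a six-membered non-aromatic ring therefore produces no readable change in this assay. This is the only step at this position with a number at both ends; the step to compound 3 ends at a limit: the limit of > 20000 nM in this assay, at which 2 of the 4 values shown sit.

Open, from the compounds shown here alone, is whether a morpholine ring or a longer aminoalkyl chain at this carbon would move the number beyond the scatter.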